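From a sulfanyl to a sulfonyl group

The source may hold more compounds than are shown below. What is called first, only, known or untested is meant among the compounds shown, and "the series" means these compounds.

In a functional assay on DU-145 cells (Homo sapiens) for inhibition, read by trypan blue exclusion, with a stated time of 96 h (a higher number here means a weaker inhibitor of growth, a lower number a stronger inhibitor of growth), compound 1 `O=C(/C(=C\c1ccccc1OCc1ccccc1)Sc1ccc(F)cc1)c1ccc(Cl)cc1` gives 1000 nM. It stands level with its two measured neighbours: compound 2 `COc1ccccc1/C=C(/SCc1ccc(Cl)cc1)C(=O)c1ccc(Cl)cc1` gives 1000 nM, and compound 3 `O=C(O)c1ccc(C(=O)/C(=C\c2ccc(Cl)c([N+](=O)[O-])c2)SCc2ccc(C(F)(F)F)cc2)cc1` gives 1000 nM. None of the three therefore stands out from the others.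

Compound 4 `O=C(/C(=C\c1ccccc1OCc1ccccc1)S(=O)(=O)Cc1ccc(F)cc1)c1ccc(Cl)cc1` keeps the rest of compound 1 but has (4-fluorobenzyl)sulfonyl in place of (4-fluorophenyl)sulfanyl on a double-bonded chain carbon bound to a carbonyl carbon and a double-bonded chain carbon.

Among the compounds with values here, no pair of measured compounds differs in only one place, and none of them carries a sulfonyl group, so the data offer no direct guide to this change. Still, compound 1 differs in several places from compound 3, which reads 1000 nM, so a flat picture is the cautious expectation in this assay. The expected size of the change, no change at the digits printed from compound 1 to compound 4 (within the scatter), is no step beyond the scatter, though a surprise in either direction remains possible. For compound 4 the estimate is 1000 nM, with an expected range from 250 nM to 5000 nM.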

Compound 4, concentration for 50% growth inhibition: 10000 nM
Beside the measured number, compound 4's estimate is 10-fold (1.00 log units) below it; the whole stated range lies below it.
By their numbers in this assay, from the lowest: compounds 1, 2 and 3 (each within the scatter of the next); then compound 4.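

In this assay, placing (4-fluorobenzyl)sulfonyl on a double-bonded chain carbon bound to a carbonyl carbon and a double-bonded chain carbon gives a weaker inhibitor of growth, with a 10-fold higher number from compound 1 to compound 4 (1.00 log units; beyond the scatter). Within the data shown here, this is the first step beyond the scatter, so the level values of the earlier compounds do not mean that this place tolerates any group. No measurement shown here explains the loss.

The swap changes two things at once, the sulfanyl becoming a sulfonyl and the phenyl becoming a benzyl, so this single step cannot show which change matters. From the compounds shown here alone, a compound with (4-fluorophenyl)sulfonyl or one with (4-fluorobenzyl)sulfanyl at this place would separate the two, while the effect of an amine there also remains open.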